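The source may report more compounds than this note shows. Statements on the series, on what has been measured and on what is new or still open speak of the compounds shown alone.

Measured in a functional assay on KB 3-1 cells (Homo sapiens) for cytotoxicity, read by MTT assay, with a stated time of 72 h; a higher number here means a weaker inhibitor, a lower number a stronger inhibitor:
- Compound 1 `O=C1Nc2ccccc2/C1=N/NC(=S)Nc1cccnc1`: > 50000 nM, a limit of the assay.
- Compound 2 `O=C1Nc2ccccc2/C1=N/NC(=S)NCc1ccccc1`: 11700 nM.

Among the compounds with values here, compound 2 holds the only true number so far, 11700 nM. The other entry stands at the limit of > 50000 nM in this assay, at which 1 of the 2 values shown sits.

Compound 3 `O=C1Nc2ccccc2/C1=N/NC(=S)NC1CCCCC1` carries cyclohexyl in place of benzyl on an amide-type nitrogen.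

Within the data shown here, one measured step bears on this nitrogen: an at least 4.2-fold lower number from compound 1 to compound 2 (0.63 log units; beyond the scatter). That step, benzyl in place of pyridin-3-yl, shows that the group here can shift the number, but its true size is open and it does not cover a swap of benzyl for cyclohexyl. No direction can be drawn from it, so no change beyond the scatter is expected in this assay. The expected change is a 1.1-fold lower number from compound 2 to compound 3 (0.03 log units; within the scatter). For compound 3 the estimate is 11000 nM, with an expected range of 4000 nM to 32000 nM.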

Compound 3, half-maximal inhibitory concentration: 9140 nM
For compound 3 the middle estimate is 1.2-fold (0.08 log units) above the measured one, within the range that was stated.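

In this assay, the change at this amide-type nitrogen gives a 1.3-fold lower number from compound 2 to compound 3 (0.11 log units; within the scatter), so a non-aromatic carbon ring and benzyl cannot be told apart here. Against pyridin-3-yl, the change gives an at least 5.4-fold lower number from compound 1 to compound 3 (0.73 log units; beyond the scatter), in the same direction as the benzyl step, so two carbon-only groups now stand on the same side of compound 1. The true size of both steps from compound 1 stays open because that compound gives only a limit of the assay: the limit of > 50000 nM in this assay, at which 1 of the 3 values shown sits.

As far as these compounds go, whether the lower numbers depend on a carbon-only ring or only on the absence of the pyridine ring nitrogen remains open. Phenyl directly on this nitrogen, pyridin-3-ylmethyl and a straight hexyl chain would separate these readings.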